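Triazole aryl swap on a shared spirooxindole core

The source may report more compounds than this note shows. Statements on the series, on what has been measured and on what is new or still open speak of the compounds shown alone.

Measured compounds:
compound 1 `CCOc1ccccc1-n1nncc1CN1C(=O)C2(C(C#N)=C(N)Oc3c(N)cc4nc5ccccc5nc4c32)c2ccccc21` – > 50000 nM
compound 2 `Cc1ccc(C)c(-n2nncc2CN2C(=O)C3(C(C#N)=C(N)Oc4c(N)cc5nc6ccccc6nc5c43)c3ccccc32)c1` – > 50000 nM
compound 3 `CCc1cccc(CC)c1-n1nncc1CN1C(=O)C2(C(C#N)=C(N)Oc3c(N)cc4nc5ccccc5nc4c32)c2ccccc21` – > 50000 nM

All three measured compounds share one core and differ only in the aryl group on the aromatic nitrogen of the triazole ring. In an ADME assay on L02 cells (Homo sapiens) for antiproliferative activity, read by MTT assay, with a stated time of 48 h (on this read-out lower numbers stand for stronger inhibition and higher numbers for weaker inhibition), compound 1 reaches only the upper limit of the assay, > 50000 nM. In this assay compound 2 likewise gives a limit, > 50000 nM. Compound 3 stands at the same limit, > 50000 nM, and no number is known for it. The steps a step that the two limits leave unreadable from compound 1 to compound 2, a step that the two limits leave unreadable from compound 1 to compound 3 and a step that the two limits leave unreadable from compound 2 to compound 3 therefore remain unreadable, since (the limit of > 50000 nM in this assay, at which 3 of the 3 values shown sit).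

Compound 4 `N#CC1=C(N)Oc2c(N)cc3nc4ccccc4nc3c2C12C(=O)N(Cc1cnnn1-c1cc(Cl)ccc1Cl)c1ccccc12` has not yet been measured. It differs from compound 3 by 2,5-dichlorophenyl in place of 2,6-diethylphenyl on an aromatic nitrogen. The steps from compound 1 and compound 2 to compound 3 bear on this change in that they also swap the aryl group on the same nitrogen, but their size is not readable. With nothing among the three measured compounds showing a value within the range of this assay, compound 4 is expected to sit at the same limit, so the expected step that the limit leaves unreadable from compound 3 to compound 4 is none beyond the scatter. The estimate for compound 4 is 70000 nM, with a range from 25000 nM to 200000 nM, and most likely the assay again reports only a limit.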

Compound 4, half-maximal inhibitory concentration: > 50000 nM
Compound 4 gave a limit, no number (the forecaster's own chance of this, stated with the estimate: 85%); the middle value lies beyond the limit too.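

Compound 4 also gives only a limit in this assay (> 50000 nM). The steps from compound 1, compound 2 and compound 3 to compound 4 therefore cannot be read: the limit of > 50000 nM in this assay, at which 4 of the 4 values shown sit. The compounds shown leave open whether any aryl group on this triazole nitrogen would bring the shared core within the measurable range of this assay.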